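Trifluoromethyl addition on the hydrazone aryl ring

The source may report more compounds than this note shows. Statements on the series, on what has been measured and on what is new or still open speak of the compounds shown alone.

Compound 3 `CN(C(=O)NC(=O)c1cccc(C(F)(F)F)c1)c1nc(C(F)(F)F)c(C(=O)N/N=C/c2cccc(C(F)(F)F)c2)s1` and compound 2 `CN(C(=O)NC(=O)c1cccc(C(F)(F)F)c1)c1nc(C(F)(F)F)c(C(=O)N/N=C/c2cc(C(F)(F)F)cc(C(F)(F)F)c2)s1` share one core and differ only by trifluoromethyl in place of hydrogen on an aromatic carbon. In a functional assay on HepG2 cells (Homo sapiens) for inhibition, read by MTT assay, with a stated time of 72 h (a higher number here means a weaker inhibitor, a lower number a stronger inhibitor), compound 3 gives 5.79 ug/mL, and compound 2 gives 5.38 ug/mL, so the step is a 1.1-fold lower number from compound 3 to compound 2 (0.03 log units; within the scatter). Compound 1 `CNc1nc(C(F)(F)F)c(C(=O)N/N=C/c2cccc(C(F)(F)F)c2)s1` carries a different core, and how the two cores differ is not broken down here. In this assay compound 1 gives only a limit, > 100 ug/mL, and stands at the limit of > 100 ug/mL in this assay, at which 1 of the 3 values shown sits. Compound 4 `CNc1nc(C(F)(F)F)c(C(=O)N/N=C/c2cc(C(F)(F)F)cc(C(F)(F)F)c2)s1` is related to compound 1 by trifluoromethyl in place of hydrogen on an aromatic carbon, the same change as that from compound 3 to compound 2. Compound 4 is therefore expected to show a number no higher from compound 1 to compound 4 (the limit leaves the size open), an expectation that rests on the small size of a 1.1-fold lower number from compound 3 to compound 2 (0.03 log units; within the scatter) and on compound 1 sitting at the limit of > 100 ug/mL in this assay, at which 1 of the 3 values shown sits. In this assay compound 4 is estimated at 100 ug/mL, expected to lie between 40 ug/mL and 250 ug/mL.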

Compound 4, half-maximal inhibitory concentration: > 100 ug/mL
Compound 4: a limit, no number; the forecaster's own chance of this, stated with the estimate: 80%; the middle value sits exactly at the limit.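

Compound 1 and compound 4 each give only a limit, not a number, in this assay, so no step between them can be read: the limit of > 100 ug/mL in this assay, at which 2 of the 4 values shown sit.

The compounds shown leave open what trifluoromethyl in place of hydrogen on an aromatic carbon does on the core of compound 1.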